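The source may hold more compounds than are shown below. What is called first, only, known or untested is meant among the compounds shown, and "the series" means these compounds.

Measured compounds in the series:

- compound 1, `NS(=O)(=O)c1ccc2nc(-n3nc(C(F)(F)F)cc3-c3ccc(Br)cc3)sc2c1`: 60%
- compound 2, `NS(=O)(=O)c1ccc2nc(-n3nc(C(F)(F)F)cc3-c3ccc(Cl)cc3)sc2c1`: 61%

In a functional assay on the whole organism (strain Wistar albino) for inhibition, with Rattus norvegicus as the target, read by paw edema, with stated times of 30 min and 3 h, at a dose of 50 mg/kg by the oral route (a higher number here means more inhibition at the dose given (going by the name of the read-out), a lower number less inhibition), compound 2 gives 61% and compound 1 gives 60%. Among the measured compounds shown here, the only measured step, a number 1 percentage points higher from compound 1 to compound 2 (within the scatter), lies within the scatter, so the two compounds cannot be separated on these numbers; compound 2 stands level with compound 1 rather than apart from it.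

Compound 3, `NS(=O)(=O)c1ccc2nc(-n3nc(C(F)(F)F)cc3-c3ccco3)sc2c1`, is not yet measured. It differs from compound 2 by furan-2-yl in place of 4-chlorophenyl on an aromatic carbon.

For the measured compounds named here, the one step on record swaps a halogen on the same six-membered ring and keeps that ring in place; it says nothing about exchanging the whole ring for furan-2-yl. Going by the values given here, no measured pair covers a change of this kind, so nothing in the data points in either direction, and the result for compound 3 is therefore expected near the number of compound 2, with a wider spread than the halogen swap would imply: the expected step is a number 9 percentage points lower from compound 2 to compound 3 (within the scatter).

Compound 3 is estimated at 52% in this assay, within a range of 32% to 68%.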

Compound 3, a percentage reported as inhibition, in the whole organism at one dose (the size of the read-out at that dose, not a potency): 61%
For compound 3 the middle estimate is 9 percentage points below the measured one; measured number inside the range.
By their numbers in this assay, from the lowest: compounds 1, 2 and 3 (each within the scatter of the next).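

In this assay the place on the five-membered aromatic ring with 2 nitrogen, next to the ring nitrogen, now proves open to exchange of the whole ring and not only of its halogen: the step is no change at the digits printed from compound 2 to compound 3 (within the scatter) for furan-2-yl in place of 4-chlorophenyl, and a number 1 percentage points higher from compound 1 to compound 3 (within the scatter) for furan-2-yl in place of 4-bromophenyl. Across these three compounds, a halogen-bearing six-membered aromatic ring of carbon only is therefore not needed to keep the read-out at this level, and the three cannot be separated even though furan-2-yl brings fewer heavy atoms and a hydrogen-bond acceptor. No measured information on hand explains why these compounds read alike.

The compounds shown leave open whether this place accepts a group without an aromatic ring, such as cyclohexyl, or a ring carrying an amine or a carboxylic acid. They also leave open whether compound 2 and compound 3 would stay level at another dose, as a single-dose percentage gives the size of the effect and not a potency.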